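Moving the fluorine on the carbamate aryl group

The source may report more compounds than this note shows. Statements on the series, on what has been measured and on what is new or still open speak of the compounds shown alone.

The two measured compounds share one core and differ only at an oxygen on the aromatic ring. Compound 1 `CC(C)=CCC/C(C)=C/CC1Cc2c(O)cc(=O)n(CCCO)c2CC1(C)C` carries a hydrogen there, and in a functional assay on PANC-1 cells (Homo sapiens) for inhibition, read by MTT assay, with a stated time of 24 h, tested at 10 uM (a higher number here means more inhibition at the concentration tested (going by the name of the read-out), a lower number less inhibition), compound 1 gives 28.7%. Compound 2 `CC(C)=CCC/C(C)=C/CC1Cc2c(OC(=O)Nc3ccc(F)cc3)cc(=O)n(CCCO)c2CC1(C)C` carries a (4-fluorophenyl)carbamoyl group instead, and in this assay compound 2 gives 43.9%, the higher of the two numbers. Going by the values given here, the only step recorded so far, a number 15.2 percentage points higher from compound 1 to compound 2 (beyond the scatter), describes adding this carbamate group and nothing else.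

Compound 3 `CC(C)=CCC/C(C)=C/CC1Cc2c(OC(=O)Nc3ccccc3F)cc(=O)n(CCCO)c2CC1(C)C` keeps the carbamate and changes only which position of the attached ring bears the fluorine: 2-fluorophenyl in place of 4-fluorophenyl on an amide-type nitrogen. Among the compounds with values here, no measured step compares two fluorine positions on this ring, so the step from compound 1 to compound 2 gives no direct guide to this change. With the same atoms joined differently, the expected step of a number 3.9 percentage points lower from compound 2 to compound 3 (within the scatter) is small, with no clear direction beyond the scatter. The estimate for compound 3 in this assay is therefore 40%, expected to lie between 24% and 56%.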

Compound 3, a percentage reported as inhibition, at one concentration (the size of the read-out at that concentration, not a potency): 71.6%
Estimate against measurement, compound 3: 31.6 percentage points below; the measured number lies above the stated range.
By their numbers in this assay, from the lowest: compound 1; then compound 2; then compound 3.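

In this assay, the place of the fluorine on the carbamate's aryl ring turns out to matter: 2-fluorophenyl in place of 4-fluorophenyl on the amide-type nitrogen gives a number 27.7 percentage points higher from compound 2 to compound 3 (beyond the scatter) even though the two groups hold the same atoms. Earlier, only the effect of adding one carbamate could be seen, whereas (2-fluorophenyl)carbamoyl in place of hydrogen on the oxygen now gives a number 42.9 percentage points higher from compound 1 to compound 3 (beyond the scatter) and so shows that, across these three compounds, the size of the gain depends on the aryl ring and not merely on a carbamate being present. Nothing available here explains why moving the fluorine changes the number this much.

The compounds shown leave open whether fluorine is needed at all, which a plain phenyl group on the same nitrogen, or a chlorine atom or a methoxy group in place of the fluorine, could help to settle. They also leave open whether the carbamate link itself matters, since an ester or an ether joining an aryl ring to the same oxygen might behave differently.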